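The compounds below may be only part of what the source reports. "The series", "measured", "known", "first", "only" and "open" are said of these compounds alone.

Of the compounds shown here, two of a shared core have been tested in an ADME assay on WI-38 cells (Homo sapiens) for inhibition, read by MTT assay, with a stated time of 72 h; a lower number here means a stronger inhibitor, a higher number a weaker inhibitor. Compound 1 `CCCCCCc1cn(Cc2cc(=O)oc3cc(O)ccc23)nn1` gives 58500 nM. Compound 2 `O=c1cc(Cn2cc(CNS(=O)(=O)c3ccc(Cl)cc3)nn2)c2ccc(O)cc2o1` gives 820 nM, the lowest of the two numbers, and its nearest neighbour is compound 1, whose number is higher by a gap well beyond the usual scatter; since these two structures differ in more than one place, only the two values themselves can be compared. Compound 3 `O=c1cc(Cn2cc(CNS(=O)(=O)c3ccc([N+](=O)[O-])cc3)nn2)c2ccc(O)cc2o1` has not yet been measured. It differs from compound 2 by nitro in place of chloro on an aromatic carbon, which in words is nitro in place of chloro on an aromatic carbon. Among the compounds with values here, no step between measured compounds tells what this exchange does here. The expected step of a 1.5-fold higher number from compound 2 to compound 3 (0.17 log units; within the scatter) in this assay is therefore small, most likely none beyond the scatter, with a slight lean toward a higher number. Compound 3 is estimated at 1200 nM, within a range from 300 nM to 5000 nM.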

Compound 3, half-maximal inhibitory concentration: < 10 nM
Compound 3 ended at the assay's limit; the forecaster's own chance of this, stated with the estimate: 3%; at least 120-fold (2.07 log units) between middle value and limit.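

Compounds 1 and 2 differ in more than one place, so they could not show what a single group on the aromatic ring does. The exchange of chloro for nitro, on an aromatic carbon para to a large group, now gives an at least 82-fold lower number from compound 2 to compound 3 (1.91 log units; beyond the scatter) in this assay, so the activity in this assay depends strongly on this one position, and a change of a single group there can produce a large step. The value of compound 3 is a limit of the assay and not a number: the limit of < 10 nM in this assay, at which 1 of the 3 values shown sits.

Going by these compounds, only chloro and nitro appear at this position, so it remains open whether an amine or a methoxy group there would give a number close to that of compound 2 or that of compound 3. On these data alone, what in the nitro group carries the step also remains open, as does the full size of the step.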